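The source may hold more compounds than are shown below. What is called first, only, known or untested is meant among the compounds shown, and "the series" means these compounds.

The compounds measured so far, all in an assay for inhibition of Fatty-acid amide hydrolase 1 (Rattus norvegicus); on this read-out higher numbers stand for weaker inhibition and lower numbers for stronger inhibition:

Compound 1, `O=C(CCCCCCc1ccccc1)c1nc(-c2ccccn2)no1`, gives 3 nM; 0.34 nM (2 entries).
Compound 2, `Cn1nnc(C(=O)CCCCCCc2ccccc2)n1`, gives 10 nM.
Compound 3, `O=C(CCCCCCc1ccccc1)c1nc(-c2cccc(Cl)n2)no1`, gives 1 nM.

Compound 1 appears twice in this assay, and its two entries, (the several entries of compound 1 in this assay, 3 nM; 0.34 nM (2 entries)), do not settle on a single number, so it offers no fixed point of comparison. Among the compounds with one number, compound 3 stands lowest; its nearest neighbour is compound 2, whose number is higher by an amount beyond the usual scatter of repeated measurements. All three share most of their structure and differ in the aromatic ring attached to the carbonyl.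

Compound 4, `O=C(CCCCCCc1ccccc1)c1nc(-c2cccc(Br)n2)no1`, is not yet measured. It differs from compound 3 in one place: bromo in place of chloro on an aromatic carbon. One halogen replaces another on the same aromatic carbon. Among the measured compounds shown here, no measured pair shows such a swap, so there is no step to lean on. For a change of this size, the expected step from compound 3 to compound 4 is no change at the digits printed from compound 3 to compound 4 (within the scatter), that is, nothing beyond the scatter. Compound 4 is therefore expected to give about 1 nM in this assay, within a range from 0.3 nM to 3.5 nM.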

Compound 4, inhibition constant: 0.63 nM
Compound 4: the middle estimate sits 1.6-fold (0.20 log units) above what was measured; low and high end bracket the measured number.
By their numbers in this assay, from the lowest: compounds 4 and 3 (each within the scatter of the next); then compound 2.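

In this assay, the change from 6-chloropyridin-2-yl to 6-bromopyridin-2-yl gives a 1.6-fold lower number from compound 3 to compound 4 (0.20 log units; within the scatter). Among the compounds shown here, this is the first step that can be read between two compounds differing in one place, which the earlier compounds could not offer, as no two of them formed such a pair. It shows that on this aromatic carbon, next to the ring nitrogen, one halogen can take the place of the other without a difference that this measurement can separate from ordinary repeat-to-repeat variation, though that holds only for these two halogens at this one place.

On these data alone, whether a halogen at this place matters at all stays open, because the compound without one gives no single number to compare against: the several entries of compound 1 in this assay, 3 nM; 0.34 nM (2 entries) Also open is how fluoro, a methyl group, an amine or a carboxylic acid on this same carbon would compare with chloro and bromo.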